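The source may hold more compounds than are shown below. What is called first, only, known or untested is meant among the compounds shown, and "the series" means these compounds.

Series notes. Compound 1 `C/C(=N\NC(N)=S)c1ccc2[nH]c(-c3ccccc3)nc2c1` carries an unsubstituted phenyl on the shared core. In an ADME assay on MT4 cells (Homo sapiens) for cytotoxicity, read by MTT assay, with a stated time of 96 h (a higher number here means that more compound is tolerated, a lower number that less compound is tolerated), compound 1 gives only a limit of the assay, >= 100000 nM, as recorded under (the limit of >= 100000 nM in this assay, at which 1 of the 3 values shown sits). Compound 2 `C/C(=N\NC(N)=S)c1ccc2[nH]c(-c3ccc(Cl)cc3)nc2c1` differs from compound 1 by chloro in place of hydrogen on an aromatic carbon, and in this assay compound 2 gives 2000 nM; the step is an at least 50-fold lower number from compound 1 to compound 2 (1.69 log units; beyond the scatter). Compound 3 `C/C(=N\NC(N)=S)c1ccc2c(c1)nc(-c1ccccc1)n2C1CCCCC1` differs from compound 1 by cyclohexyl in place of hydrogen on an aromatic nitrogen; in this assay compound 3 gives 20000 nM, a step of an at least 5.0-fold lower number from compound 1 to compound 3 (0.69 log units; beyond the scatter). Compound 4 `C/C(=N\NC(N)=S)c1ccc2c(c1)nc(-c1ccc(Cl)cc1)n2C1CCCCC1`, not yet measured, differs from compound 3 by chloro in place of hydrogen on an aromatic carbon, the same change as that from compound 1 to compound 2, at the same place. Set beside the step of an at least 50-fold lower number from compound 1 to compound 2 (1.69 log units; beyond the scatter), the step from compound 3 to compound 4 is expected to be a 13-fold lower number from compound 3 to compound 4 (1.12 log units; beyond the scatter), resting on that one pair. Compound 4 is therefore estimated at 1500 nM, between 400 nM and 8000 nM.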

Compound 4, half-maximal cytotoxic concentration: 17000 nM
The estimate for compound 4 lay 11-fold (1.05 log units) below the measured number; measured number above the stated range.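

On the core bearing cyclohexyl, phenyl to 4-chlorophenyl gives a 1.2-fold lower number from compound 3 to compound 4 (0.07 log units; within the scatter), so the change seen on the core of compound 1 does not carry over in this assay: the same change on two cores in this assay, an at least 50-fold lower number (1.69 log units; beyond the scatter) from compound 1 to compound 2 and a 1.2-fold lower number (0.07 log units; within the scatter) from compound 3 to compound 4, at least 42-fold (1.62 log units) apart, beyond the scatter of two such steps. Read the other way, cyclohexyl in place of hydrogen on the aromatic nitrogen gives an 8.5-fold higher number from compound 2 to compound 4 (0.93 log units; beyond the scatter), opposite in direction to its step without chloro: the same change on two cores in this assay, an at least 5.0-fold lower number (0.69 log units; beyond the scatter) from compound 1 to compound 3 and an 8.5-fold higher number (0.93 log units; beyond the scatter) from compound 2 to compound 4, at least 42-fold (1.62 log units) apart, beyond the scatter of two such steps. Compound 1 carries only a limit of the assay, >= 100000 nM, and a single pair on each core shows neither the true size of the gap nor a reason for it.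

Still open, on these data alone, is whether the same split appears with fluoro or methoxy in place of chloro. Also open, as far as these compounds go, is whether it appears with methyl in place of cyclohexyl.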